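The compounds below may be only part of what the source reports. "The series", "measured", "known", "first", "only" and "open" are said of these compounds alone.

Measured in a functional assay on A549 cells (Homo sapiens) for antiproliferative activity, read by MTT assay, with a stated time of 48 h; on this read-out lower numbers stand for stronger inhibition and higher numbers for weaker inhibition:
- Compound 1 `Cn1cc(C2=C(c3nn(CCCn4cncn4)c4ncccc34)C(=O)N(c3ccccc3)C2=O)c2ccccc21`: > 100000 nM (a limit of the assay)
- Compound 2 `Cn1cc(C2=C(c3nn(CCCN4CCCCC4)c4ncccc34)C(=O)N(c3ccccc3)C2=O)c2ccccc21`: 20600 nM
- Compound 3 `Cn1cc(C2=C(c3nn(CCCn4cccc4)c4ncccc34)C(=O)NC2=O)c2ccccc21`: > 100000 nM (a limit of the assay)

Compound 3 gives > 100000 nM in this assay, and this is a limit, not a number. It therefore stands at the limit of > 100000 nM in this assay, at which 2 of the 3 values shown sit, and compound 1 is the other compound there.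

Compound 4 `Cn1cc(C2=C(c3nn(CCCN4CCCCC4)c4ncccc34)C(=O)NC2=O)c2ccccc21` keeps the rest of compound 3 and changes only the group at the end of the chain: piperidin-1-yl in place of 1H-pyrrol-1-yl on a saturated chain carbon, three bonds along the chain from an aromatic nitrogen.

Within the data shown here, one measured step bears on this change. There, piperidin-1-yl entered at the same place in place of 1H-1,2,4-triazol-1-yl, and the result was an at least 4.8-fold lower number from compound 1 to compound 2 (0.68 log units; beyond the scatter). The comparison is imperfect, since the group that leaves is a different one and the core of compound 1 differs from the core of compound 3. Even so, a step of similar size toward a lower number is expected in this assay, with compound 2 at 20600 nM as the nearest guide.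

The expected change is an at least 5.5-fold lower number from compound 3 to compound 4 (0.74 log units; beyond the scatter). For compound 4 the estimate is 18000 nM, with an expected range of 5000 nM to 70000 nM.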

Compound 4, half-maximal inhibitory concentration: > 100000 nM
Compound 4: only a limit was reported; the forecaster's own chance of this, stated with the estimate: 15%; at least 5.5-fold (0.74 log units) between middle value and limit.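

The step from compound 3 to compound 4 cannot be read, because both values are limits of the assay, and one more compound now sits at the same limit: the limit of > 100000 nM in this assay, at which 3 of the 4 values shown sit.

The step that can be read is an at least 4.8-fold higher number from compound 2 to compound 4 (0.68 log units; beyond the scatter), and it shows that in this assay the piperidin-1-yl group does not give a measurable number on its own: the result also depends on what sits on the amide-type nitrogen in a ring. Compound 2, at 20600 nM, is the only one of the four with a measured number, so the lower number seen with piperidin-1-yl in the phenyl-bearing series does not carry over to the series with hydrogen on that nitrogen.

From the compounds shown here alone, it remains open whether a small group such as methyl on that nitrogen, in place of phenyl or hydrogen, would keep a measurable number like that of compound 2. Going by these compounds, it is also open whether another amine at the end of the chain, such as morpholine or dimethylamine, or a shorter or longer chain than the propyl one, would bring the hydrogen-bearing compounds below the limit.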